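Dropping the amine tail: from amide to ketone

The compounds below may be only part of what the source reports. "The series", "measured", "known", "first", "only" and "open" are said of these compounds alone.

Compound 2 `CCn1cc(C(CC)(CC)c2ccc(C#CC(O)(CC)CC)c(C)c2)cc1C(=O)NCCCN(C)C` is the weaker of the two measured compounds in an assay on cells for agonist activity at vitamin D3 receptor (Homo sapiens), read by microscopy (on this read-out lower numbers stand for an effect already at smaller amounts and higher numbers for an effect only at larger amounts of compound), where compound 2 gives 142 nM, while compound 1 `CCN(CC)CCNC(=O)c1cc(C(CC)(CC)c2ccc(C#CC(O)(CC)CC)c(C)c2)cn1CC` gives 6.98 nM. Going by the values given here, the only measured step, a 20-fold higher number from compound 1 to compound 2 (1.31 log units; beyond the scatter), shows that the amine-bearing tail matters. Compound 3 `CCCCC(=O)c1cc(C(CC)(CC)c2ccc(C#CC(O)(CC)CC)c(C)c2)cn1CC` goes further and removes that tail entirely: butyl in place of (3-(dimethylamino)propyl)amino on a carbonyl carbon. Among the compounds with values here, no measured step covers such a change, so the direction is open; the expectation for compound 3 is a modest shift, a 1.4-fold higher number from compound 2 to compound 3 (0.15 log units; within the scatter), with wide uncertainty. Compound 3 is estimated at 200 nM, within 20 nM to 2000 nM.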

Compound 3, half-maximal effective concentration: > 50 nM
Compound 3: a limit, no number; the forecaster's own chance of this, stated with the estimate: 10%; the middle value is on the limit's open side.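

In this assay compound 3 gives > 50 nM, which is a limit and not a number. Even so, butyl on the carbonyl carbon gives an at least 7.1-fold higher number from compound 1 to compound 3 (0.85 log units; beyond the scatter), so this chain does not keep the low number of the diethylamino amide. Going by these compounds, the step from compound 2 to compound 3 cannot be read, and whether butyl sits level with or beyond the dimethylamino tail stays unknown.

The compounds shown do not separate the part played by the amide nitrogen from that of the terminal amine. A plain butyl amide and a ketone whose chain ends in diethylamino would pull these two apart.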